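The source may hold more compounds than are shown below. What is called first, only, known or untested is meant among the compounds shown, and "the series" means these compounds.

- Compound 1 `CC(c1cc(=O)[nH]c(N(C)C)n1)c1c(F)cccc1F`: 89000 nM
- Compound 2 `Cc1c(C(C)c2c(F)cccc2F)nc(N(C)C)[nH]c1=O`: > 17000 nM, a limit
- Compound 3 `CCc1c(C(C)c2c(F)cccc2F)nc(N(C)C)[nH]c1=O`: > 81000 nM, a limit

These three compounds were tested in an ADME assay on MT4 cells (Homo sapiens) for cytotoxicity, read by MTT assay, with a stated time of 4 days; on this read-out lower numbers stand for higher toxicity in this test and higher numbers for lower toxicity in this test. Only compound 1 has a true number, and it is 89000 nM. Compound 2 stands at > 17000 nM, which is a limit of the assay and not a number, as the limit of > 17000 nM in this assay, at which 1 of the 3 values shown sits, records. Compound 3 also has only a limit, as the limit of > 81000 nM in this assay, at which 1 of the 3 values shown sits, records.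

The next compound, compound 4 `Cc1c(C(C)c2c(F)cccc2F)nc(N2CCCC2)[nH]c1=O`, keeps compound 2 unchanged except at one place: pyrrolidin-1-yl takes the place of dimethylamino on an aromatic carbon (pyrrolidin-1-yl in place of dimethylamino on an aromatic carbon).

The measured steps offer little guidance. These are a step that the limit leaves unreadable from compound 1 to compound 2, a step that the limit leaves unreadable from compound 1 to compound 3 and a step that the two limits leave unreadable from compound 2 to compound 3. None has a readable size, and each changes a different place from the one altered here. Going by the values given here, no measured step therefore predicts a change in either direction, so no step beyond the usual scatter is expected in this assay, with compound 1 at 89000 nM as the only numerical anchor. The expected change is a step that the limit leaves unreadable from compound 2 to compound 4. For compound 4, the estimated value is 45000 nM, with an expected range of 15000 nM to 130000 nM.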

Compound 4, half-maximal cytotoxic concentration: > 78000 nM
Compound 4 was reported as a limit; the forecaster's own chance of this, stated with the estimate: 55%; middle value at least 1.7-fold (0.23 log units) away from the limit.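

Compound 2 and compound 4 each carry only a limit and not a number, so no size can be read for the step between them, where pyrrolidin-1-yl replaces dimethylamino. As far as these compounds go, whether that replacement changes the result in this assay at all, and in which direction, stays open.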